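The compounds below may be only part of what the source reports. "The series", "measured", "known", "first", "only" and "open" are said of these compounds alone.

Measured so far:
compound 1 `CN1CCN(CCCCOc2cc(C(=O)N3CCCCc4sccc43)ccc2NC(=O)c2ccccc2-c2ccccc2)CC1`, in an assay on CHO cells for inhibition of Vasopressin V2 receptor (Homo sapiens), read by radioligand binding (on this read-out lower numbers stand for stronger inhibition and higher numbers for weaker inhibition), compound 1 gives 1 nM
compound 2 `O=C(Nc1ccc(C(=O)N2CCCCc3sccc32)cc1O)c1ccccc1-c1ccccc1`, in this assay compound 2 gives only a limit, < 10 nM

Compound 2 stands on a limit, not a number, so its distance from compound 1 cannot be read. The step that the limit leaves unreadable from compound 1 to compound 2 is therefore of unknown size (the limit of < 10 nM in this assay, at which 1 of the 2 values shown sits). Compound 3 `CN(C)C1CCN(C(=O)COc2cc(C(=O)N3CCCCc4sccc43)ccc2NC(=O)c2ccccc2-c2ccccc2)CC1` carries ((4-(dimethylamino)piperidin-1-yl)carbonyl)methyl in place of hydrogen on an oxygen on an aromatic ring. No readable measured step bears on this oxygen. Guided by compound 1 with 1 nM, compound 3 is expected to land close to it, a step that the limit leaves unreadable from compound 2 to compound 3. Compound 3 is estimated at 1.5 nM, between 0.4 nM and 6 nM.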

Compound 3, half-maximal inhibitory concentration: 8 nM
Compound 3: the middle estimate sits 5.3-fold (0.73 log units) below what was measured; measured number outside the range, above it.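

In this assay, (4-(dimethylamino)piperidin-1-yl)carbonyl in place of 3-(4-methylpiperazin-1-yl)propyl on the saturated chain carbon bound to the oxygen gives an 8.0-fold higher number from compound 1 to compound 3 (0.90 log units; beyond the scatter). Among these compounds, this is the first readable step at this oxygen, and it shows that the read-out responds to the group carried there. The steps involving compound 2 cannot be read: the limit of < 10 nM in this assay, at which 1 of the 3 values shown sits.

Going by these compounds, the two groups differ in more than one feature, so it stays open whether the step follows the carbonyl or the change of ring. Also open, on these data alone, is how a plain methyl or a carboxylic acid on a chain would read on this oxygen.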